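Chloro in Place of Nitro on an Aryl Hydrazone

The source may hold more compounds than are shown below. What is called first, only, known or untested is meant among the compounds shown, and "the series" means these compounds.

Measured so far:
- Compound 1, `C/C(=N/NC(=O)Nc1nc(-c2ccc(C)cc2)cc(-c2ccc(F)cc2)n1)c1ccc(Cl)cc1`: 100 mg/kg
- Compound 2, `C/C(=N/NC(=O)Nc1nc(-c2ccc(C)cc2)cc(-c2ccc(Cl)cc2)n1)c1ccc([N+](=O)[O-])cc1`: 300 mg/kg

Of the compounds shown here, two have been tested in a functional assay on the whole organism (strain Albino) with Mus musculus as the target, with a stated time of 4 h; on this read-out lower numbers stand for an effect already at smaller amounts and higher numbers for an effect only at larger amounts of compound. Compound 1 gives 100 mg/kg in this assay, and compound 2 gives 300 mg/kg. Compound 2 therefore stands at the higher of the two numbers, and its gap to compound 1 lies beyond the usual scatter of repeated measurements. For the measured compounds named here, these two compounds differ from each other in more than one place, so their values show only that compound 2 needs a larger dose than compound 1, and nothing about the contribution of any single group.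

Compound 3, `C/C(=N/NC(=O)Nc1nc(-c2ccc(C)cc2)cc(-c2ccc(Cl)cc2)n1)c1ccc(Cl)cc1`, has not yet been measured. It is derived from compound 2 by one change: chloro in place of nitro on an aromatic carbon. For this change a step toward a smaller dose is expected, of modest size, because compound 2 starts from 300 mg/kg and the remaining compound 1 sits at a lower number. The step from compound 2 to compound 3 is estimated as a 2.0-fold lower number from compound 2 to compound 3 (0.30 log units; within the scatter) in this assay. Compound 3 is expected to give about 150 mg/kg, within a range from 70 mg/kg to 350 mg/kg.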

Compound 3, dose for half-maximal effect: 300 mg/kg
Compound 3: middle estimate off by 2.0-fold (0.30 log units), on the low side; low and high end bracket the measured number.
By their numbers in this assay, from the lowest: compound 1; then compounds 2 and 3 (each within the scatter of the next).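

In this assay, chloro in place of nitro on an aromatic carbon, para to a large group, gives no change at the digits printed from compound 2 to compound 3 (within the scatter), so this exchange of the 4-nitrophenyl for the 4-chlorophenyl group leaves the dose needed unchanged within the usual scatter, even though a group of three heavy atoms gives way to a single atom. For the compounds shown here, the second single change, with chloro where fluoro stood on a different ring, gives a 3.0-fold higher number from compound 1 to compound 3 (0.48 log units; beyond the scatter) in this assay, and of the two changes that can now be read on their own, only this one moves the number beyond the scatter. The data offer no independent measurement that could explain either outcome.

On these data alone, each change rests on a single pair of compounds, so it remains open whether the fluoro-to-chloro step would be the same size with nitro in place of the chloro on the other ring. As far as these compounds go, it is also open how a different group at the nitro position, such as an amine or a carboxylic acid, would shift the dose.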